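The source may report more compounds than this note shows. Statements on the series, on what has been measured and on what is new or still open speak of the compounds shown alone.

Notes on the series. Three compounds with a shared core have been run in a functional assay on SK-N-SH cells (Homo sapiens) for inhibition, read by MTT assay, with a stated time of 72 h, tested at 50 uM; a lower number here means less inhibition of growth, a higher number more inhibition of growth at the concentration tested. Compound 2 `C=CCc1ccc(OCc2cn(-c3ccc(OC)cc3)nn2)c(O)c1` gives 68.5%, the second highest of the three numbers. Compound 1 `C=CCc1ccc(OCc2cn(-c3ccc(C#N)cc3)nn2)c(O)c1` gives 62.5%; the step of a number 6 percentage points higher from compound 1 to compound 2 (within the scatter) is within the scatter, so the two read as the same. Compound 3 `C=CCc1ccc(OCc2cn(-c3cccc(C#N)c3)nn2)c(O)c1` gives 78.8%; the step of a number 10.3 percentage points higher from compound 2 to compound 3 (beyond the scatter) lies beyond the scatter, as does a number 16.3 percentage points higher from compound 1 to compound 3 (beyond the scatter).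

Compound 4 `C=CCc1ccc(OCc2cn(-c3ccc(C(=O)c4ccccc4)cc3)nn2)c(O)c1` is not yet measured. Its change against compound 2 is benzoyl in place of methoxy on an aromatic carbon. Going by the values given here, the only measured step that changes the group at that aromatic carbon is a number 6 percentage points higher from compound 1 to compound 2 (within the scatter), which stayed within the scatter. The steps of a number 16.3 percentage points higher from compound 1 to compound 3 (beyond the scatter) and a number 10.3 percentage points higher from compound 2 to compound 3 (beyond the scatter) exchange the whole group on the aromatic nitrogen and bear on this change only loosely. Among the compounds with values here, no measured compound carries a benzoyl group, so the expected size of the step in this assay rests on a single comparison; the expectation is a step of no size beyond the scatter, in either direction. Compound 4 is estimated at 66%, with a range of 50% to 82%. The step this estimate means, a number 2.5 percentage points lower from compound 2 to compound 4 (within the scatter), is expected to stay within the scatter.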

Compound 4, percent growth inhibition at one concentration: 58.1%
Beside the measured number, compound 4's estimate is 7.9 percentage points above it, and the stated range covers the measured number.
By their numbers in this assay, from the lowest: compounds 4, 1 and 2 (each within the scatter of the next, the first and the last beyond it); then compound 3.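

In this assay the group on this aromatic carbon, para to a large group, is no longer without any readable effect: with benzoyl in place of methoxy, the step of a number 10.4 percentage points lower from compound 2 to compound 4 (beyond the scatter) is the only one at this carbon to pass the scatter, and it is modest. With benzoyl in place of cyano, the step of a number 4.4 percentage points lower from compound 1 to compound 4 (within the scatter) stays within the scatter, so the three groups do not fall into clearly separate levels, and only methoxy and benzoyl read apart. A benzoyl group brings a further six-membered aromatic ring to this carbon, yet compound 4 still gives 58.1% at the concentration tested.

Going by these compounds, whether an amine or a carboxylic acid on this aromatic carbon would stay level with these three groups remains open. Nothing available speaks to what lies behind these steps.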